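Fluoro to methyl on the sulfonyl aromatic ring: compound 3

The source may report more compounds than this note shows. Statements on the series, on what has been measured and on what is new or still open speak of the compounds shown alone.

Measured so far:
compound 1, `O=C1O[C@H]([C@@H](O)Cn2cc(CNS(=O)(=O)c3ccc(F)cc3)nn2)C(OCc2ccccc2)=C1OCc1ccccc1`: 30 nM
compound 2, `COc1ccccc1-c1cn(C/C=C2\OC(=O)C(OCc3ccccc3)=C2OCc2ccccc2)nn1`: > 100000 nM

In an ADME assay on HFF cells (Homo sapiens) for cytotoxicity, read by MTT assay, with a stated time of 72 h (a lower number here means a stronger inhibitor, a higher number a weaker inhibitor), compound 1 gives 30 nM. Compound 2 reaches only the limit of this assay, > 100000 nM; this is a limit, not a number. Compound 1 therefore stands as the only number shown, the other value being a limit (the limit of > 100000 nM in this assay, at which 1 of the 2 values shown sits).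

Compound 3, `Cc1ccc(S(=O)(=O)NCc2cn(C[C@H](O)[C@H]3OC(=O)C(OCc4ccccc4)=C3OCc3ccccc3)nn2)cc1`, differs from compound 1 by methyl in place of fluoro on an aromatic carbon. Among the compounds with values here, no measured step covers this change. Methyl in place of fluoro on an aromatic carbon is expected to leave this assay essentially unchanged, so the step of a 1.3-fold higher number from compound 1 to compound 3 (0.12 log units; within the scatter) is estimated to lie within the scatter. Compound 3 is estimated at 40 nM, between 15 nM and 120 nM.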

Compound 3, half-maximal inhibitory concentration: 50 nM
The estimate for compound 3 lay 1.3-fold (0.10 log units) below the measured number; measured number inside the range.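

Within the data shown here, the 4-fluorophenyl to 4-methylphenyl change gives, in this assay, a 1.7-fold higher number from compound 1 to compound 3 (0.22 log units; within the scatter), the first measured step at this position. Fluoro and methyl on this ring are therefore not told apart in this assay. Nothing at hand bears on a cause for this step.

Going by these compounds, whether an amine, a carboxylic acid or a longer chain at this position would stay within the scatter of compound 1 remains open. Compound 2, whose value is a limit, differs from compound 1 in more than one place and says nothing about this position.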